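This account rests on a few compounds, and the source may have more. Where it says the series, first, only, none or still open, it means among the compounds named here.

Measured so far in a functional assay on NCI/ADR cells (Homo sapiens) for inhibition, read by sulforhodamine B assay, with a stated time of 48 h; a lower number here means a stronger inhibitor of growth, a higher number a weaker inhibitor of growth:

compound 1, `O=c1ccoc(/C=C/c2ccccc2)c1`, gives 514 uM
compound 2, `COc1ccc(/C=C/c2cc(=O)cco2)cc1`, gives 310 uM
compound 3, `COc1ccc(/C=C/C2CC=CC(=O)O2)cc1OC`, gives 11.6 uM

Compound 1 and compound 2 share one core. Compound 2 differs from compound 1 by methoxy in place of hydrogen on an aromatic carbon, and this step gives a 1.7-fold lower number from compound 1 to compound 2 (0.22 log units; within the scatter), so the two values are taken as the same.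

Compound 3 is built on a different core; the difference between the core of compound 1 and the core of compound 3 is not broken down here. Compound 3 stands lowest of the three numbers, beyond the scatter from both compound 2 and compound 1.

Compound 4, `COc1cc(OC)c(OC)cc1/C=C/C1CC=CC(=O)O1`, is not yet measured in this assay. It differs from compound 3 by methoxy in place of hydrogen on an aromatic carbon. This is the same kind of change as from compound 1 to compound 2, but the place is not the same: in compound 2 the entering methoxy sits para to a group of 9 heavy atoms, whereas in compound 4 it sits ortho to a group of 9 heavy atoms, meta to a methoxy group and para to a methoxy group, on the core of compound 3 rather than that of compound 1.

Within the data shown here, the expected step from compound 3 to compound 4 is a 1.3-fold lower number from compound 3 to compound 4 (0.11 log units; within the scatter), resting on the single earlier example, where the change gave a 1.7-fold lower number from compound 1 to compound 2 (0.22 log units; within the scatter); the different surroundings and the different core leave this expectation loosely founded. Compound 4 is therefore estimated at 9 uM in this assay, expected to fall between 3 uM and 30 uM.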

Compound 4, concentration for growth inhibition (reported as GI): 9.4 uM
For compound 4 the middle estimate is 1.0-fold (0.02 log units) below the measured one; low and high end bracket the measured number.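

In this assay, methoxy in place of hydrogen on an aromatic carbon gives a 1.2-fold lower number from compound 3 to compound 4 (0.09 log units; within the scatter), so the two values on this second core are taken as the same. Set beside the earlier example, the change reads alike on both cores: the same change on two cores in this assay, a 1.7-fold lower number (0.22 log units; within the scatter) from compound 1 to compound 2 and a 1.2-fold lower number (0.09 log units; within the scatter) from compound 3 to compound 4, 1.3-fold (0.13 log units) apart, within the scatter of two such steps. Among these compounds, this supports carrying the change between these two cores only as a step that stays within the scatter; it shows no measurable effect of the methoxy group on either core, and with only two pairs it is no general rule, all the more as the entering methoxy stands ortho to a group of 9 heavy atoms, meta to a methoxy group and para to a methoxy group in compound 4 but in a different place in compound 2.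

On the aromatic ring the compounds shown carry only hydrogen and methoxy, so it stays open whether a hydroxyl group, an amine or a carboxylic acid on that ring would give a step beyond the scatter on either core. No pair shown differs in the core alone, so what the core itself contributes to the values also stays open.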